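The source may hold more compounds than are shown below. What is called first, only, known or untested is meant among the compounds shown, and "the series" means these compounds.

Measured so far in a functional assay on MCF7 cells (Homo sapiens) for inhibition, read by sulforhodamine B assay; a lower number here means a stronger inhibitor of growth, a higher number a weaker inhibitor of growth:

Compound 1, `FC(F)(F)Oc1ccc(-c2ccc(-c3ccc(-c4nc5ccccc5[nH]4)cc3)cc2)cc1`: 38400 nM
Compound 2, `Oc1ccc(-c2ccc(-c3ccc(-c4nc5ccccc5[nH]4)cc3)cc2)cc1`: 30500 nM
Compound 3, `Oc1cccc2[nH]c(-c3ccc(-c4ccc(-c5ccc(OC(F)(F)F)cc5)cc4)cc3)nc12`: 2210 nM

Compound 2 differs from compound 1 in a single place: hydrogen in place of trifluoromethyl on an oxygen on an aromatic ring. That change gave a 1.3-fold lower number from compound 1 to compound 2 (0.10 log units; within the scatter), so the two compounds are not distinguishable in this assay. Compound 3 differs from compound 1 at the core: hydroxy in place of hydrogen on an aromatic carbon. This change gave a 17-fold lower number from compound 1 to compound 3 (1.24 log units; beyond the scatter), and compound 3 therefore stands as the strongest inhibitor of growth among the three.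

Compound 4, `Oc1ccc(-c2ccc(-c3ccc(-c4nc5c(O)cccc5[nH]4)cc3)cc2)cc1`, has not yet been measured in this assay. It differs from compound 3 by hydrogen in place of trifluoromethyl on an oxygen on an aromatic ring. This is the same change as from compound 1 to compound 2, at a place described in the same words, made here on the core of compound 3. Among the measured compounds shown here, because the one measured example of this change gave a 1.3-fold lower number from compound 1 to compound 2 (0.10 log units; within the scatter), a step of about the same small size is expected here: a 1.2-fold lower number from compound 3 to compound 4 (0.09 log units; within the scatter). On that basis compound 4 is estimated to give 1800 nM in this assay, likely between 700 nM and 5000 nM. This expectation rests on a single prior example, made on a core without the hydroxy group.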

Compound 4, concentration for 50% growth inhibition: 190 nM
Compound 4: middle estimate off by 9.5-fold (0.98 log units), on the high side; measured number outside the range, below it.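

Replacing trifluoromethyl with hydrogen on the oxygen did not carry over as the same step, for on the core that bears the extra hydroxy group it gave a 12-fold lower number from compound 3 to compound 4 (1.07 log units; beyond the scatter), and so the size of this step depends on the core: the same change on two cores in this assay, a 1.3-fold lower number (0.10 log units; within the scatter) from compound 1 to compound 2 and a 12-fold lower number (1.07 log units; beyond the scatter) from compound 3 to compound 4, 9.2-fold (0.97 log units) apart, beyond the scatter of two such steps

Seen from the other side, adding the hydroxy group to the core gave a 160-fold lower number from compound 2 to compound 4 (2.21 log units; beyond the scatter), so that change is not a fixed step either: the same change on two cores in this assay, a 17-fold lower number (1.24 log units; beyond the scatter) from compound 1 to compound 3 and a 160-fold lower number (2.21 log units; beyond the scatter) from compound 2 to compound 4, 9.2-fold (0.97 log units) apart, beyond the scatter of two such steps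

Both comparisons rest on the same four compounds, so they show one interaction between the two changes in this assay, and they do not show how it arises or whether it would appear on any other core.

The compounds shown leave open whether this large step needs a hydroxy group in particular, as an amine or a carboxylic acid in its place might give a different result. As far as these compounds go, it also remains open whether the same interaction would appear in cells other than MCF7.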